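A few compounds are considered here, and "the series" means these few. Any claim that something is new, unique, unknown or untested is made for them only; others in the source may bear on it.

Measured compounds in an ADME assay on RAW264.7 cells (Mus musculus) for cytotoxicity, read by MTT assay, with a stated time of 72 h, tested at 50 ug/mL; on this read-out lower numbers stand for less inhibition and higher numbers for more inhibition at the one concentration tested (going by the name of the read-out):

Compound 1 `O=C(c1nc2ccccc2s1)N1CCN(c2ccncc2)CC1`: 62%
Compound 2 `O=C(c1nc2cc(C(F)(F)F)ccc2s1)N1CCN(c2cnccn2)CC1`: 28.1%
Compound 3 `CC(=O)N1CCN(C(=O)c2nc3cc(C(F)(F)F)ccc3s2)CC1`: 20.2%

Compound 3 holds the lowest of the three numbers in this assay. Its nearest neighbour is compound 2, whose number lies higher by a margin inside the usual scatter, so the two cannot be told apart; compound 1 lies well beyond that scatter above compound 3.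

The next compound, compound 4 `O=C(c1nc2cc(C(F)(F)F)ccc2s1)N1CCN(c2ccncc2)CC1`, differs from compound 3 in one place: pyridin-4-yl in place of acetyl on an amine nitrogen in a ring. Among the measured compounds shown here, the one measured step that bears on a change at this ring nitrogen is a number 7.9 percentage points lower from compound 2 to compound 3 (within the scatter), which swapped one six-membered aromatic group for acetyl and moved the number only within the scatter. Compound 1 carries the same pyridin-4-yl group as compound 4 but also lacks the trifluoromethyl group, so its value alone cannot fix the size of this step. A small step in this assay is therefore expected, most likely upward, and compound 4 is estimated at 32%, between 18% and 50%, an expected step of a number 11.8 percentage points higher from compound 3 to compound 4 (beyond the scatter).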

Compound 4, a percentage reported as inhibition, at one concentration (the size of the read-out at that concentration, not a potency): 17.5%
Compound 4: middle estimate off by 14.5 percentage points, on the high side; the measured number lies below the stated range.
By their numbers in this assay, from the lowest: compounds 4, 3 and 2 (each within the scatter of the next, the first and the last beyond it); then compound 1.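

In this assay, the step of a number 2.7 percentage points lower from compound 3 to compound 4 (within the scatter) shows that putting pyridin-4-yl in place of acetyl on the amine nitrogen in the ring makes no measurable difference, even though one group is an aromatic ring and the other has no ring. The two aromatic groups can still be told apart, with pyridin-4-yl in place of pyrazin-2-yl giving a number 10.6 percentage points lower from compound 2 to compound 4 (beyond the scatter), a modest step. With pyridin-4-yl held fixed, trifluoromethyl in place of hydrogen on an aromatic carbon gives a number 44.5 percentage points lower from compound 1 to compound 4 (beyond the scatter), far larger than any step listed at the ring nitrogen.

From the compounds shown here alone, it remains open whether a chlorine on that aromatic carbon, or a carboxylic acid on the ring nitrogen, would shift the number in this assay. Nothing shown here accounts for the size of these steps.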